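This account rests on a few compounds, and the source may have more. Where it says the series, first, only, none or still open, it means among the compounds named here.

Among the measured compounds shown here, compound 2 `O=C(O)c1cc(-c2cccc(COc3ccc4c(c3)CN(C3CCC3)C4=O)c2)ccc1Cl` gives 90.3% in an assay on HEK293 cells for positive allosteric modulation of metabotropic glutamate receptor 2 (Rattus norvegicus), read by thallium flux (a lower number here means a smaller maximal response, a higher number a larger maximal response), the higher of the two numbers so far. Its neighbour, compound 1 `CC(C)N1Cc2cc(OCc3cccc(-c4ccc(Cl)c(C(=O)O)c4)c3)ccc2C1=O`, gives 88.1%, and the step of a number 2.2 percentage points higher from compound 1 to compound 2 (within the scatter) stays within the scatter. Compound 3 `O=C(O)c1cc(-c2cccc(COc3ccc4c(c3)CN(C3CC3)C4=O)c2)ccc1Cl` differs from compound 2 by one change: cyclopropyl in place of cyclobutyl on an amide-type nitrogen in a ring. For the measured compounds named here, the only measured step that bears on this change is the swap of one small alkyl group for another on the same ring nitrogen, and it moved the maximal response little. For compound 3 the step of a number 2.3 percentage points lower from compound 2 to compound 3 (within the scatter) is therefore expected to be small, with no clear direction. Compound 3 is estimated at 88%, in a range from 78% to 98%.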

Compound 3, largest response reached (Emax), in percent of the reference or control that the assay uses: 64.9%
Estimate against measurement, compound 3: 23.1 percentage points above; measured number below the stated range.
By their numbers in this assay, from the lowest: compound 3; then compounds 1 and 2 (each within the scatter of the next).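

In this assay this ring nitrogen proves less forgiving than the first swap suggested: a number 25.4 percentage points lower from compound 2 to compound 3 (beyond the scatter) follows cyclopropyl replacing cyclobutyl, and a number 23.2 percentage points lower from compound 1 to compound 3 (beyond the scatter) follows cyclopropyl replacing isopropyl. Small alkyl groups here are therefore not interchangeable, and among these three only cyclopropyl stands apart, while isopropyl and cyclobutyl remain within the scatter of each other. No available evidence explains this difference. Still open, going by these compounds, is whether a cyclopentyl group or a longer chain such as n-butyl on this nitrogen would keep the maximal response of compound 2 or lose it as compound 3 does.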